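This account rests on a few compounds, and the source may have more. Where it says the series, first, only, none or still open, it means among the compounds named here.

Compound 1 `CCCC[S+]([O-])c1sc2nc(-c3nccs3)cc(-c3ccc(CNC(C)=O)cc3)c2c1N` gives 2.5 nM in an assay for inhibition of 15-hydroxyprostaglandin dehydrogenase [NAD(+)] (Homo sapiens), read by fluorescence, with a stated time of 15 min, in the presence of a further agent that is not named here (a lower number here means a stronger inhibitor, a higher number a weaker inhibitor), the lowest of the two numbers recorded. Compound 2 `CCC[S+]([O-])c1sc2nc(-c3cccs3)cc(C(=O)N(C)C)c2c1N` gives 14.7 nM in this assay, a higher number that lies beyond the scatter of the method. Compound 3 `CCCC[S+]([O-])c1sc2nc(-c3nccs3)cc(-c3ccc(COC(=O)NCC)cc3)c2c1N` has not yet been measured. It differs from compound 1 in one place: (ethylcarbamoyl)oxy in place of acetamido on a saturated chain carbon bound to an aromatic carbon. Going by the values given here, no measured pair shows this change, so its effect is not known from these data; the expected step of a 1.6-fold higher number from compound 1 to compound 3 (0.20 log units; within the scatter) is small, either a slight weakening or none beyond the scatter. Compound 3 is estimated at 4 nM, with a range from 1.5 nM to 12 nM.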

Compound 3, half-maximal inhibitory concentration: 3.4 nM
Beside the measured number, compound 3's estimate is 1.2-fold (0.07 log units) above it; the range from low to high includes it.
By their numbers in this assay, from the lowest: compounds 1 and 3 (each within the scatter of the next); then compound 2.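

In this assay replacing acetamido with (ethylcarbamoyl)oxy on a saturated chain carbon bound to an aromatic carbon gives a 1.4-fold higher number from compound 1 to compound 3 (0.13 log units; within the scatter) and so stays within the scatter. This place on the core of compound 1 therefore takes the larger group, which has one more hydrogen-bond acceptor, with no measurable loss. Nothing available here bears on why the two groups give such similar numbers.

From the compounds shown here alone, whether an amine or a carboxylic acid at this place would keep the number as low remains open. So does the effect of a chain longer than the ethyl of compound 3.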